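From compound 2 to compound 3

This account rests on a few compounds, and the source may have more. Where it says the series, first, only, none or still open, it means among the compounds named here.

In an ADME assay on GES1 cells (Homo sapiens) for inhibition, read by MTT assay, with a stated time of 72 h (a lower number here means a stronger inhibitor, a higher number a weaker inhibitor), compound 1 `Cc1cc(Nc2cc(-c3ccccc3)[nH]n2)n2nc(SCc3cccc(Br)c3)nc2n1` gives > 50000 nM and this is a limit of the assay. Going by the values given here, compound 2 `Cc1cc(Nc2cc(-c3ccccc3)[nH]n2)n2nc(SCCCc3ccccc3)nc2n1` gives 40200 nM as the only actual number so far. In compound 3 `Cc1ccc(CSc2nc3nc(C)cc(Nc4cc(-c5ccccc5)[nH]n4)n3n2)cc1` the difference 4-methylphenyl in place of phenethyl on a saturated chain carbon bound to a sulfur puts 4-methylphenyl in place of phenethyl on a saturated chain carbon bound to a sulfur. Among the compounds with values here, the one measured step of an at least 1.2-fold lower number from compound 1 to compound 2 (0.09 log units; that floor lies within the scatter) falls at that same place and its floor lies within the scatter, so no step beyond the scatter is expected in this assay here. The estimate therefore means a 1.0-fold higher number from compound 2 to compound 3 (0.02 log units; within the scatter) as the expected step. Compound 3 is estimated at 42000 nM with 20000 nM to 85000 nM as its expected range.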

Compound 3, half-maximal inhibitory concentration: 36200 nM
The estimate for compound 3 lay 1.2-fold (0.06 log units) above the measured number; measured number inside the range.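

In this assay, the new result gives a 1.1-fold lower number from compound 2 to compound 3 (0.05 log units; within the scatter), so a second actual number at this place shows that 4-methylphenyl and phenethyl on a saturated chain carbon bound to a sulfur cannot be told apart. Against compound 1 the result reads an at least 1.3-fold lower number from compound 1 to compound 3 (0.14 log units; that floor lies within the scatter). The value of compound 1 is a limit, so this step is only a floor: the limit of > 50000 nM in this assay, at which 1 of the 3 values shown sits. The compounds shown leave open whether an amine, a carboxylic acid or a longer chain at this place would give a number clearly apart from these.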